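A few compounds are considered here, and "the series" means these few. Any claim that something is new, unique, unknown or untested is made for them only; others in the source may bear on it.

Measured so far:
Compound 1, `Cc1cc(O)cc(-c2nn(CC#N)cc2-c2ccnc(-c3ccc(Oc4ccccc4)cc3)c2)c1`: 88%
Compound 2, `COc1cc(C)cc(-c2nn(CC#N)cc2-c2ccnc(-c3ccc(N(C)C)cc3)c2)c1`: 105%

In a functional assay on RXF 393 cells (Homo sapiens) for cytotoxicity, read by sulforhodamine B assay, with a stated time of 48 h, tested at 0.001 uM (a higher number here means a weaker effect of the compound at the concentration tested, a lower number a stronger effect), compound 1 gives 88%, while compound 2 gives 105%. Of the two numbers, compound 2 stands highest, and its nearest neighbour, compound 1, lies lower by a gap beyond the usual scatter; compound 2 is therefore the weaker of the two at the tested concentration.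

Compound 3, `Cc1cc(O)cc(-c2nn(CC#N)cc2-c2ccnc(-c3ccc(N(C)C)cc3)c2)c1`, has not yet been measured. It differs from compound 2 in one place: hydrogen in place of methyl on an oxygen on an aromatic ring. Among the compounds with values here, compound 1 also carries a hydroxy group, but compound 1 and compound 2 differ in a second place as well, so no single step among the measured compounds isolates this change; only the two values can be set side by side. For the step from compound 2 to compound 3 the expectation is a number 7 percentage points lower from compound 2 to compound 3 (within the scatter), a shift that is not expected to exceed the scatter, leaning, if anywhere, downwards. Compound 3 is therefore estimated at 98%, expected to fall between 82% and 112%.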

Compound 3, a percentage reported as activity, at one concentration (the size of the read-out at that concentration, not a potency): 100%
For compound 3 the middle estimate is 2 percentage points below the measured one; the measured number falls inside the stated range.
By their numbers in this assay, from the lowest: compound 1; then compounds 3 and 2 (each within the scatter of the next).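

In this assay, the change from methoxy to hydroxy gives a number 5 percentage points lower from compound 2 to compound 3 (within the scatter), so with dimethylamino held constant, the methyl on this oxygen makes no readable difference at the tested concentration. Compound 3 also provides the single-change link that compound 1 and compound 2 lacked, since those two differ in two places: dimethylamino in place of phenoxy on an aromatic carbon gives a number 12 percentage points higher from compound 1 to compound 3 (beyond the scatter), which places the readable difference at that aromatic carbon, although the step is modest. Nothing available gives a reason for either step.

The compounds shown leave open whether the change from methoxy to hydroxy would read the same with phenoxy in place of dimethylamino, and whether the phenoxy step would hold at other concentrations, since a single-concentration read-out is not a potency. They also leave open what a longer ether such as ethoxy, or an amine in place of the hydroxy, would do to the 3-hydroxy-5-methylphenyl group's read-out.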